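Swapping a hydroxy group for a larger amine group

A few compounds are considered here, and "the series" means these few. Any claim that something is new, unique, unknown or untested is made for them only; others in the source may bear on it.

Compound 1 `CCC(=O)N(c1ccc(Cl)c(Cl)c1)C1CCCC1O` gives 20 mg/kg
Compound 2 `CCC(=O)N(c1cccc(OC)c1)C1CCCC1N(C)C` gives 4 mg/kg
Compound 3 `CCC(=O)N(c1ccc(F)c(Cl)c1)C1CCCC1N(C)C` gives 0.7 mg/kg

In a functional assay on the whole organism for positive allosteric modulation, with Mus musculus as the target (a lower number here means that less compound is needed, a higher number that more compound is needed for the effect), compound 1 stands highest of the three at 20 mg/kg and so needs the most compound to reach the effect. Compound 2 and compound 3 both lie lower, beyond the usual scatter.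

The unmeasured compound 4 `CCC(=O)N(c1ccc(Cl)c(Cl)c1)C1CCCC1N(C)CCN(C)C` differs from compound 1 in one place. The change is (2-(dimethylamino)ethyl)(methyl)amino in place of hydroxy on a saturated ring carbon and it puts (2-(dimethylamino)ethyl)(methyl)amino in place of hydroxy on a saturated ring carbon, next to the ring atom that bears a large group.

Within the data shown here, no measured pair isolates a swap of this kind, so the evidence is indirect. Compound 2 at 4 mg/kg and compound 3 at 0.7 mg/kg both carry a dimethylamino group where compound 1 has its hydroxy, although their other substituents differ from those of compound 1 too. Among the measured compounds shown here, nothing measured so far tests the larger group that enters here, so the expectation stays loose.

The expected step is a 5.0-fold lower number from compound 1 to compound 4 (0.70 log units; beyond the scatter) in this assay and it would be a drop beyond the scatter. Compound 4 is estimated at 4 mg/kg with an expected range of 0.8 mg/kg to 20 mg/kg around that figure.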

Compound 4, dose for half-maximal effect: 20 mg/kg
Beside the measured number, compound 4's estimate is 5.0-fold (0.70 log units) below it; measured number inside the range.
By their numbers in this assay, from the lowest: compound 3; then compound 2; then compounds 1 and 4 (each within the scatter of the next).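

In this assay, placing (2-(dimethylamino)ethyl)(methyl)amino in place of hydroxy on a saturated ring carbon gives no change at the digits printed from compound 1 to compound 4 (within the scatter), and this is the first pair shown that differs in one place only. It shows that, with the rest of the core of compound 1 held constant, this position accepts a group of 7 heavy atoms in place of a single oxygen, and the loss of the hydrogen-bond donor leaves the dose in this whole-animal test unmoved. No measurement shown explains why the two groups give the same reading.

What the compounds leave open is how smaller or different groups would read at this ring carbon on the same core, such as a plain amino group, a methoxy group or the dimethylamino group carried by other compounds in the set. From the compounds shown here alone, it is also open whether a carboxylic acid or a longer chain with a terminal amine would still leave the number in place.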